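This account rests on a few compounds, and the source may have more. Where it says the series, first, only, none or still open, it means among the compounds named here.

Of the compounds shown here, three have so far been measured in a functional assay (HSMC cells, Homo sapiens) for antiproliferative activity, with a stated time of 72 h; a lower number here means a stronger inhibitor, a higher number a weaker inhibitor. Compound 1 `COC(=O)[C@H](CCSC)NC(=O)c1ccc(C(=O)NC[C@H]2COc3ccccc3O2)cc1-c1ccccc1OC` gives 252000 nM in this assay. Compound 2 `COC(=O)[C@H](CCSC)NC(=O)c1ccc(C(=O)NC[C@@H]2COc3ccccc3O2)cc1-c1ccccc1OC`, which has the same atoms and bonds and differs only in the drawn configuration at one saturated ring carbon, gives 647000 nM. Compound 3 `COC(=O)CNC(=O)c1ccc(C(=O)NC[C@H]2COc3ccccc3O2)cc1-c1ccccc1OC`, in which hydrogen sits in place of the 2-(methylsulfanyl)ethyl group on a saturated chain carbon bound to an amide-type nitrogen and a carbonyl carbon, gives 122000 nM, the lowest of the three numbers and therefore the strongest inhibitor of this small set. The step of a 2.1-fold lower number from compound 1 to compound 3 (0.32 log units; beyond the scatter) was modest but beyond the scatter.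

Compound 4 `COC(=O)CNC(=O)c1ccc(C(=O)NC[C@@H]2COc3ccccc3O2)cc1-c1ccccc1OC` has not yet been measured. Its relation to compound 3 mirrors that of compound 2 to compound 1: the two compounds have the same atoms and bonds and differ only in configuration as drawn: 1 of 1 stereo elements differ; a stereocentre at a saturated ring carbon is drawn S in compound 3 and R in compound 4. For the measured compounds named here, the one measured step that bears on this change is a 2.6-fold higher number from compound 1 to compound 2 (0.41 log units; beyond the scatter), where the drawn S configuration at the ring carbon gave the lower number, a difference that rests on (the fact that compounds 1 and 2 differ only in the configuration as drawn). Carrying that step over, a modest rise in the same direction is expected, so the step of a 2.6-fold higher number from compound 3 to compound 4 (0.42 log units; beyond the scatter) is estimated. Compound 4 is accordingly expected to give 320000 nM in this assay, with a likely range from 150000 nM to 650000 nM.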

Compound 4, half-maximal inhibitory concentration: 76000 nM
Estimate against measurement, compound 4: 4.2-fold (0.62 log units) above, and the stated range ends above it.
By their numbers in this assay, from the lowest: compounds 4 and 3 (each within the scatter of the next); then compound 1; then compound 2.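

In this assay, the preference at the saturated ring carbon does not carry over from one side chain to the other: with the 2-(methylsulfanyl)ethyl group present, the step was a 2.6-fold higher number from compound 1 to compound 2 (0.41 log units; beyond the scatter), but with hydrogen in its place it is a 1.6-fold lower number from compound 3 to compound 4 (0.21 log units; within the scatter), so no preference between the two drawn configurations can be read for this pair. The replacement of 2-(methylsulfanyl)ethyl by hydrogen, seen here as an 8.5-fold lower number from compound 2 to compound 4 (0.93 log units; beyond the scatter), therefore depends on the configuration at the ring carbon, and the two changes do not simply add up: the same change on two cores in this assay, a 2.1-fold lower number (0.32 log units; beyond the scatter) from compound 1 to compound 3 and an 8.5-fold lower number (0.93 log units; beyond the scatter) from compound 2 to compound 4, 4.1-fold (0.62 log units) apart, beyond the scatter of two such steps. The replacement gives a lower number on both configurations, and no pair among these four compounds goes against that direction, although its size differs between them.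

The compounds shown leave open whether the difference between configurations belongs to 2-(methylsulfanyl)ethyl alone or would also appear with another group on that chain carbon, such as a methyl or a benzyl group. They also leave open how a carboxylic acid in place of the methyl ester would behave with either configuration.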